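A Second Methoxy Group Enters the Aryl Ring

This account rests on a few compounds, and the source may have more. Where it says the series, first, only, none or still open, it means among the compounds named here.

Three compounds have been measured in a functional assay for inhibition, read by Griess assay, with a stated time of 150 min, tested at 1 mM; on this read-out higher numbers stand for more inhibition at the one concentration tested (going by the name of the read-out) and lower numbers for less inhibition:
compound 1 `COc1ccc(/C(Cl)=C/C=C(\C#N)C(=O)c2c(C)[nH]c3ccccc23)cc1` gives 74%
compound 2 `COc1ccc(/C(Cl)=C/C=C(\C#N)C(=O)c2c[nH]c3ccc(Br)cc23)cc1` gives 56.2%
compound 3 `COc1ccc(/C(Cl)=C/C=C(\C#N)C(=O)c2c[nH]c3ccccc23)cc1` gives 76.9%

Compound 1 stands second highest of the three. Its nearest neighbour is compound 3, with a number 2.9 percentage points higher from compound 1 to compound 3 (within the scatter), a difference that falls within the scatter. Compound 2 lies furthest away: the step of a number 20.7 percentage points higher from compound 2 to compound 3 (beyond the scatter) shows that taking the bromo group away from the core raises the read-out by a modest amount that lies beyond the scatter.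

Compound 4 `COc1ccc(/C(Cl)=C/C=C(\C#N)C(=O)c2c(C)[nH]c3ccccc23)cc1OC` is the next compound to be measured. It differs from compound 1 in one place: methoxy in place of hydrogen on an aromatic carbon. The new methoxy group sits on an aromatic carbon of a six-membered aromatic ring of carbon only, ortho to a methoxy group and meta to a large group.

Neither measured step bears directly on this change. Both measured steps concern the other end of the shared core, where a methyl or a bromo group was exchanged for hydrogen, and the only one of them beyond the scatter involved the bromo group. Nothing measured speaks to a methoxy group entering the aryl ring. On that basis no step beyond the scatter is expected in this assay from compound 1 to compound 4, in either direction. Compound 4 is therefore estimated at 71%, with a range from 55% to 85%, which corresponds to an expected step of a number 3 percentage points lower from compound 1 to compound 4 (within the scatter).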

Compound 4, a percentage reported as inhibition, at one concentration (the size of the read-out at that concentration, not a potency): 75.8%
Compound 4: the middle estimate sits 4.8 percentage points below what was measured, and the stated range covers the measured number.
By their numbers in this assay, from the lowest: compound 2; then compounds 1, 4 and 3 (each within the scatter of the next).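

Within the data shown here, the aryl ring had not varied among compound 1, compound 2 and compound 3, so this is the first reading of a change there: in this assay, methoxy in place of hydrogen on an aromatic carbon, ortho to a methoxy group and meta to a large group, gives a number 1.8 percentage points higher from compound 1 to compound 4 (within the scatter). At this position, then, a group of 2 heavy atoms can replace hydrogen without separating compound 4 from compound 1 beyond the scatter, at the one concentration tested. Nothing available offers an explanation for this result.

As far as these compounds go, whether the same position would give a similar reading with an amine, a carboxylic acid or a longer chain such as butoxy remains open, as does whether the same methoxy group would behave alike on the core of compound 3, which has hydrogen in place of the methyl group. With only one concentration shown, it also remains open whether compound 1 and compound 4 would stay within the scatter of each other at other concentrations.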